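This account rests on a few compounds, and the source may have more. Where it says the series, first, only, none or still open, it means among the compounds named here.

Compound 1, `O=C(Nc1ccnnc1)c1cc(C(F)(F)F)ccc1OCc1ccccc1`, is the starting point of this account. In a physicochemical assay for lipophilicity, at pH 7.4 (a lower number here means a more polar compound, a higher number a more lipophilic compound), compound 1 gives 5.4. Going by the values given here, only one other compound has been measured so far, compound 2, `O=C(Nc1cccc(F)c1)c1cc(C(F)(F)F)ccc1OCc1ccc(F)cc1`, which in this assay gives 8.2, a number that lies beyond the usual scatter above the value of compound 1; the two structures differ in more than one place, so no single step joins them, and compound 1 simply stands as the lower of the two numbers known. The compound still to be measured is compound 3, `O=C(Nc1ccnnc1)c1cc(N2CCC(O)CC2)ccc1OCc1ccccc1`. Compared with compound 1 it carries 4-hydroxypiperidin-1-yl in place of trifluoromethyl on an aromatic carbon. Among the compounds with values here, no measured pair shows this exchange on its own, so its effect has to be estimated from the structures alone. In this assay the expected step is a number 1.80 log units lower from compound 1 to compound 3 (beyond the scatter), a fall that would lie well beyond the scatter rather than within it. Compound 3 is therefore estimated at 3.6, with a likely range from 2.6 to 4.6.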

Compound 3, distribution coefficient: 3.2
Beside the measured number, compound 3's estimate is 0.40 log units above it, within the range that was stated.
By their numbers in this assay, from the lowest: compound 3; then compound 1; then compound 2.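

Going by these compounds alone, the exchange of trifluoromethyl for 4-hydroxypiperidin-1-yl, on the aromatic carbon meta to a (pyridazin-4-yl)carbamoyl group and para to a benzyloxy group, gives the first step in this assay that can be read at a single place, and that step is a number 2.20 log units lower from compound 1 to compound 3 (beyond the scatter) and counts as large. This position on the core of compound 1 can therefore shift the number by a large amount through one exchange alone, something the earlier pair could not show, as compound 1 and compound 2 differ in more than one place. No measurement at hand bears on what lies behind this step.

Going by these compounds, in this one pair the ring, its nitrogen and its hydroxyl enter together, so what each of them contributes to the step remains open. Also open, on these data alone, is whether a plain piperidine without the hydroxyl, a morpholine or a carboxylic acid on the same carbon would give a step of similar size, and whether the exchange would give the same step on the core of compound 2.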